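The source may report more compounds than this note shows. Statements on the series, on what has been measured and on what is new or still open speak of the compounds shown alone.

Compound 1 `Cc1nc(N)c2c(-c3cccs3)cn([C@@H]3O[C@H](CO)[C@@H](O)[C@H]3O)c2n1` and compound 2 `COc1nc(N)nc2c1c(-c1cccs1)cn2[C@@H]1O[C@H](CO)[C@@H](O)[C@H]1O` both carry a thiophen-2-yl group on the shared core; the difference between the two cores is not broken down here. In a functional assay on HepG2 cells (Homo sapiens) for antiproliferative activity, read by XTT assay, with a stated time of 72 h (a higher number here means a weaker inhibitor, a lower number a stronger inhibitor), compound 1 gives > 20000 nM, which is a limit of the assay rather than a number. In this assay compound 2 likewise gives > 20000 nM, again a limit. Compound 3 `C#Cc1cn([C@@H]2O[C@H](CO)[C@@H](O)[C@H]2O)c2nc(C)nc(N)c12` arises from compound 1 by the change (ethynyl in place of thiophen-2-yl on an aromatic carbon). In this assay compound 3 gives > 20000 nM, also a limit. The step that the two limits leave unreadable from compound 1 to compound 3 therefore cannot be read, since both of its ends sit at the limit of > 20000 nM in this assay, at which 3 of the 3 values shown sit.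

Compound 4 `C#Cc1cn([C@@H]2O[C@H](CO)[C@@H](O)[C@H]2O)c2nc(N)nc(OC)c12` has not yet been measured. It arises from compound 2 by the same change, (ethynyl in place of thiophen-2-yl on an aromatic carbon), at a place described in exactly the same words as for the earlier pair. Because every value in this set sits at the limit of > 20000 nM in this assay, at which 3 of the 3 values shown sit, the earlier step offers no size to carry over, only the observation that it left compound 3 at the same limit as compound 1. The step from compound 2 to compound 4 is accordingly expected to be about a step that the limit leaves unreadable from compound 2 to compound 4, resting on nothing more than that observation. Compound 4 is expected to give roughly 30000 nM in this assay, with a plausible range from 15000 nM to 100000 nM, and most probably the assay will again report only a limit for compound 4.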

Compound 4, half-maximal inhibitory concentration: > 20000 nM
Compound 4 was reported as a limit; the forecaster's own chance of this, stated with the estimate: 90%; the middle value does not contradict the limit.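

The step from compound 2 to compound 4 cannot be read in this assay, because both of its ends are limits of the assay and not numbers: the limit of > 20000 nM in this assay, at which 4 of the 4 values shown sit. With no number among them, the compounds shown leave open whether ethynyl in place of thiophen-2-yl changes antiproliferative activity on either core, and how the two cores compare.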